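Piperidinyl to oxazolyl amide: tolerance in a cell toxicity assay

The compounds below may be only part of what the source reports. "The series", "measured", "known", "first", "only" and "open" are said of these compounds alone.

Compound 1, `Cn1c(-c2ccccc2)cnc1NC(=O)c1ccc(F)cc1`, gives > 100000 nM in a toxicity assay on THP-1 cells (Homo sapiens) for inhibition (a lower number here means that less compound is tolerated, a higher number that more compound is tolerated), a limit rather than a number.
Compound 2, `COc1ccc(-c2cnc(NC(=O)C3CCNCC3)n2C)cc1`, gives > 100000 nM, again a limit.
Compound 3, `Cn1c(-c2ccccc2Cl)cnc1NC(=O)c1ccc(F)cc1`, gives > 50000 nM, also a limit.

Compound 2 therefore stands at the limit of > 100000 nM in this assay, at which 2 of the 3 values shown sit, where compound 1 also sits, with nothing below that limit resolved. Within the data shown here, the one step between measured compounds, a step that the two limits leave unreadable from compound 1 to compound 3, involves chloro in place of hydrogen on an aromatic carbon and cannot be read because both ends are limits. Compound 4, `COc1ccc(-c2cnc(NC(=O)c3cnco3)n2C)cc1`, differs from compound 2 by 1,3-oxazol-5-yl in place of piperidin-4-yl on a carbonyl carbon. Among the measured compounds shown here, no measured step touches this kind of change, so only the shared limits guide the expectation: compound 4 is expected to tolerate a similar amount, a number no higher from compound 2 to compound 4 (the limit leaves the size open), with no step beyond the scatter. The estimate for compound 4 is 100000 nM, in the range 30000 nM to 300000 nM.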

Compound 4, half-maximal cytotoxic concentration: > 100000 nM
Compound 4 gave a limit, no number; the forecaster's own chance of this, stated with the estimate: 80%; the middle value lies on the limit itself.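

Compound 2 and compound 4 both give only limits in this assay, so the step between them cannot be read. The compounds shown leave open at what concentration any of them would become toxic to these cells.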